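Swapping the Side Group of Compound 3

This account rests on a few compounds, and the source may have more. Where it says the series, first, only, none or still open, it means among the compounds named here.

Of the compounds shown here, three that share one core have so far been tested in a functional assay on MCF7 cells (Homo sapiens) for inhibition, read by MTT assay, with a stated time of 48 h, tested at 10 uM (a lower number here means less inhibition of growth, a higher number more inhibition of growth at the concentration tested), to see how strongly each holds back cancer cell growth. Compound 1 (`Cc1cc(=O)c2c(O)cc(OCc3ccc([N+](=O)[O-])cc3)c([C@H]3CCN(C)C[C@H]3O)c2o1`) gives 39% and compound 2 (`Cc1cc(=O)c2c(O)c(CN3CCC(N4CCCCC4)CC3)c(O)c([C@H]3CCN(C)C[C@H]3O)c2o1`) gives 25%, while compound 3 (`Cc1cc(=O)c2c(O)c(CN3CCCC3)c(O)c([C@H]3CCN(C)C[C@H]3O)c2o1`) gives 12% and so stands lowest, with both gaps beyond the usual scatter.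

The next compound to consider is compound 4 (`CCOC(=O)N1CCN(Cc2c(O)c([C@H]3CCN(C)C[C@H]3O)c3oc(C)cc(=O)c3c2O)CC1`), which has not yet been measured. It carries 4-(ethoxycarbonyl)piperazin-1-yl in place of pyrrolidin-1-yl on a saturated chain carbon bound to an aromatic carbon.

Among the compounds with values here, no two measured compounds differ in only one place, so there is no direct example of what such a swap does. Compound 2, which also carries a larger group than pyrrolidin-1-yl at that place, gives 25% and offers the nearest hint, though a single compound is thin evidence. A modest rise in this assay is therefore expected, with an estimated a number 12 percentage points higher from compound 3 to compound 4 (beyond the scatter) as the size of the step. For compound 4 the estimated value is 24% with an expected range from 10% to 40% as its likely span.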

Compound 4, percent growth inhibition at one concentration: 31%
Estimate against measurement, compound 4: 7 percentage points below; the measured number falls inside the stated range.
By their numbers in this assay, from the lowest: compound 3; then compounds 2, 4 and 1 (each within the scatter of the next, the first and the last beyond it).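

Within the data shown here, this swap is the first single change on the shared core that can be read directly: in this assay, replacing pyrrolidin-1-yl with 4-(ethoxycarbonyl)piperazin-1-yl on a saturated chain carbon bound to an aromatic carbon gives a number 19 percentage points higher from compound 3 to compound 4 (beyond the scatter). Among these compounds, it shows that growth inhibition at the concentration tested responds to the group held at this place, which the earlier compounds could not show because each differs from the others in more than one place. The entering group also changes several things at once, with more heavy atoms, a six-membered ring in place of a five-membered one, a second ring nitrogen and an added ethoxycarbonyl part, and nothing measured here bears on why the number rises.

From the compounds shown here alone, it remains open which of these parts accounts for the step, and whether other groups at this place would move the number in the same direction. A plain piperazin-1-yl group, with a free amine in the ring, would help separate the contribution of the ring from that of the ethoxycarbonyl part.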